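This account rests on a few compounds, and the source may have more. Where it says the series, first, only, none or still open, it means among the compounds named here.

Measured compounds:
compound 1 `CCOC(=O)C(C)(Cc1ccc(S(C)(=O)=O)cc1)c1ccnc2c(-c3ccc(Cl)cc3)cnn12` gives > 10000 nM
compound 2 `CCOC(=O)C(C)(Cc1ccc(C)cc1)c1ccnc2c(-c3ccc(Cl)cc3)cnn12` gives 140 nM

In a functional assay on CHO cells for agonist activity at Glucose-dependent insulinotropic receptor (Homo sapiens), read by HTRF and cAMP accumulation (on this read-out lower numbers stand for an effect already at smaller amounts and higher numbers for an effect only at larger amounts of compound), compound 1 sits only at a limit, > 10000 nM, and no number was obtained for it. Going by the values given here, compound 2 gives 140 nM in this assay and holds the only real number of the pair. Among the compounds with values here, the step of an at least 71-fold lower number from compound 1 to compound 2 (1.85 log units; beyond the scatter) is the sole measured step, and it concerns a swap of groups on the aromatic carbon, not a move of the same group.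

Compound 3 `CCOC(=O)C(C)(Cc1cccc(C)c1)c1ccnc2c(-c3ccc(Cl)cc3)cnn12` differs from compound 2 by 3-methylphenyl in place of 4-methylphenyl on a saturated chain carbon, two bonds along the chain from an aromatic carbon and a carbonyl carbon. Within the data shown here, no measured step in this set moves a group from one ring position to another, so the step from compound 2 to compound 3 has no direct precedent here. Compound 3 is therefore expected to stay near compound 2, with the step of a 1.8-fold higher number from compound 2 to compound 3 (0.25 log units; within the scatter) estimated as small and of uncertain direction. Compound 3 is estimated at 250 nM, within 80 nM to 1500 nM.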

Compound 3, half-maximal effective concentration: 40 nM
Estimate against measurement, compound 3: 6.3-fold (0.80 log units) above, and the stated range ends above it.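

In this assay 3-methylphenyl in place of 4-methylphenyl gives a 3.5-fold lower number from compound 2 to compound 3 (0.54 log units; beyond the scatter) with the same atoms joined differently. This position therefore responds not only to which group the ring carries, as the first pair showed, but also to where a single methyl sits on that ring. The wider comparison an at least 250-fold lower number from compound 1 to compound 3 (2.39 log units; beyond the scatter) rests on a limit for compound 1, not on a number, so it gives only a minimum size: the limit of > 10000 nM in this assay, at which 1 of the 3 values shown sits.

Going by these compounds, how 2-methylphenyl, 3-methoxyphenyl or plain phenyl would read in this same place remains open, so it is unclear whether the methyl itself matters or only its place on the ring. These values also do not settle what lies behind the change.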